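This account rests on a few compounds, and the source may have more. Where it says the series, first, only, none or still open, it means among the compounds named here.

Of the compounds shown here, three that share one core have been tested in an ADME assay on HeLa Rh cells (Homo sapiens) for cytotoxicity, read by microscopy; on this read-out higher numbers stand for lower toxicity in this test and lower numbers for higher toxicity in this test. Compound 1 `COc1ccc(-c2ccc(C(O)Cc3cc(OC)c(OC)cc3[N+](=O)[O-])cc2)cc1` reaches only a limit there, > 244000 nM, and so gives no number. Compound 2 `COc1cc(CC(O)c2ccc(-c3ccc(Cl)cc3)cc2)c([N+](=O)[O-])cc1OC` gives 4100 nM, and compound 3 `COc1cc(CC(O)c2ccc(-c3cccc(C#N)c3)cc2)c([N+](=O)[O-])cc1OC` gives 5200 nM; these two numbers lie within the scatter of each other, as the step of a 1.3-fold higher number from compound 2 to compound 3 (0.10 log units; within the scatter) shows. Against compound 1 the step of an at least 46-fold lower number from compound 1 to compound 3 (1.67 log units; beyond the scatter) was large. Compound 4 `COc1cc(CC(O)c2ccc(-c3cccc(CO)c3)cc2)c([N+](=O)[O-])cc1OC` differs from compound 3 by hydroxymethyl in place of cyano on an aromatic carbon. Among the measured compounds shown here, no measured pair shows this exchange, and the chloro and cyano compounds sit close together, so compound 4 is expected to stay near compound 3, with the step of a 1.3-fold higher number from compound 3 to compound 4 (0.13 log units; within the scatter) expected to be modest. Compound 4 is estimated at 7000 nM, between 2500 nM and 40000 nM.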

Compound 4, half-maximal cytotoxic concentration: 6000 nM
Estimate against measurement, compound 4: 1.2-fold (0.07 log units) above; the measured number falls inside the stated range.
By their numbers in this assay, from the lowest: compounds 2, 3 and 4 (each within the scatter of the next). At a limit, above all of these: compound 1.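

In this assay, hydroxymethyl in place of cyano gives a 1.2-fold higher number from compound 3 to compound 4 (0.06 log units; within the scatter), so adding a hydrogen-bond donor at this position leaves no readable difference. The comparison with the chloro compound gives a 1.5-fold higher number from compound 2 to compound 4 (0.17 log units; within the scatter), so three different substituted phenyl groups now sit within the scatter of their neighbours in the series, while the comparison with the methoxy compound gives an at least 40-fold lower number from compound 1 to compound 4 (1.60 log units; beyond the scatter). Compound 1 gives only a limit, not a number: the limit of > 244000 nM in this assay, at which 1 of the 4 values shown sits.

As far as these compounds go, whether an amine or a carboxylic acid on this aromatic carbon would stay in the same range remains open. So does whether a longer chain, such as hydroxyethyl, would.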